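The compounds below may be only part of what the source reports. "The series", "measured", "known", "first", "only" and "open" are said of these compounds alone.

Three compounds have numbers in a functional assay on K562 cells (Homo sapiens) for antiproliferative activity, read by CCK-8 assay, with a stated time of 72 h; on this read-out higher numbers stand for weaker inhibition of growth and lower numbers for stronger inhibition of growth:

compound 1 `CC[C@@H]1C(=O)N(C)c2cnc(Nc3ccc(S(N)(=O)=O)cc3)nc2N1C1CCCC1`: 470 nM
compound 2 `CC[C@@H]1C(=O)N(C)c2cnc(-n3ccc4cc(C(=O)NC)ccc43)nc2N1C1CCCC1`: 705 nM
compound 3 `CCNC(=O)c1ccc2c(ccn2-c2ncc3c(n2)N(c2ccn(C)n2)C(CC)C(=O)N3C)c1`: 12800 nM

Compound 1 gives the lowest of these three numbers. Compound 2 sits close to it, a gap that lies within the usual scatter, so the two cannot be ranked against each other. Compound 3, by contrast, stands far higher than compound 1, a gap well beyond the scatter. Within the data shown here, no single-change pair links any two of these three measured compounds, so no counted step between them is available.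

Compound 4 `CC[C@@H]1C(=O)N(C)c2cnc(Nc3ccc(S(=O)(=O)Nc4ccccc4)cc3)nc2N1C1CCCC1` has not been measured in this assay. It differs from compound 1 in one place: phenyl in place of hydrogen on a sulfonamide nitrogen. Among the measured compounds shown here, nothing among the measured compounds shows what a phenyl on a sulfonamide nitrogen does, so the expectation rests on compound 1 alone. The step of a 1.7-fold higher number from compound 1 to compound 4 (0.23 log units; within the scatter) is expected to be small, if anything a mild weakening, and may well stay within the scatter. Compound 4 is therefore estimated at 800 nM in this assay, within a range of 250 nM to 2500 nM.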

Compound 4, concentration for 50% growth inhibition: 4180 nM
Beside the measured number, compound 4's estimate is 5.2-fold (0.72 log units) below it, outside the stated range (above it).
By their numbers in this assay, from the lowest: compounds 1 and 2 (each within the scatter of the next); then compound 4; then compound 3.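

In this assay, putting phenyl in place of hydrogen on a sulfonamide nitrogen gives an 8.9-fold higher number from compound 1 to compound 4 (0.95 log units; beyond the scatter), so this one change clearly weakens inhibition of growth. The earlier compounds shown here, linked by no single-change pair, could not show that this position responds to substitution; here the sulfamoyl to phenylsulfamoyl change alone moves the number beyond the scatter. Nothing available explains why this step goes the way it does. With only phenyl shown on this nitrogen, it remains open whether a methyl or a 2-hydroxyethyl group there would keep the number close to that of compound 1. Going by these compounds, it is equally open whether a phenyl carrying a carboxylic acid or an amine would recover any of the lost inhibition of growth.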